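The source may hold more compounds than are shown below. What is called first, only, known or untested is meant among the compounds shown, and "the series" means these compounds.

Measured so far:
- compound 1, `CCCCc1cnc(CCCc2ccc(-c3ccccc3C(=O)O)cc2)[nH]1`, in an in vitro functional assay on cells for agonist activity at Bombesin receptor subtype-3 (Homo sapiens), read by luminescence and calcium flux (on this read-out higher numbers stand for an effect only at larger amounts of compound and lower numbers for an effect already at smaller amounts), gives 5600 nM
- compound 2, `Cc1cccc(Cc2cnc(CCc3ccc(-c4ccccc4C(=O)O)cc3)[nH]2)c1`, in this assay gives 4310 nM

Compound 2 stands at the lower of the two values, but the gap to compound 1 is within the usual scatter, so the two are to be read as equivalent and neither can be called the more active. Compound 3, `Cc1ccc(Cc2cnc(CCc3ccc(-c4ccccc4C(=O)O)cc3)[nH]2)cc1`, has the same atoms as compound 2 joined differently: 4-methylphenyl in place of 3-methylphenyl on a saturated chain carbon bound to an aromatic carbon. Among the compounds with values here, no step between measured compounds bears on this kind of change, so there is nothing in the two known values that points in either direction. The step from compound 2 to compound 3 in this assay is expected to be a 1.0-fold higher number from compound 2 to compound 3 (0.02 log units; within the scatter), that is, none beyond the scatter. Compound 3 is therefore estimated to give about 4500 nM, in a range from 1500 nM to 13000 nM.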

Compound 3, half-maximal effective concentration: 2660 nM
For compound 3 the middle estimate is 1.7-fold (0.23 log units) above the measured one; the measured number falls inside the stated range.
By their numbers in this assay, from the lowest: compounds 3, 2 and 1 (each within the scatter of the next, the first and the last beyond it).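

In this assay, 4-methylphenyl in place of 3-methylphenyl on a saturated chain carbon bound to an aromatic carbon gives a 1.6-fold lower number from compound 2 to compound 3 (0.21 log units; within the scatter) and so leaves compound 2 and compound 3 equivalent on this read-out. Within the data shown here, this is the first step at this place, and it shows that, for these two groups, the change of methyl position does not separate the compounds beyond the scatter. Nothing available explains this outcome or tells what the read-out would do with a larger difference at this place.

Still open, going by these compounds, is whether a methoxy group, a chlorine atom or an amine on this phenyl ring, instead of the methyl, would give a step beyond the scatter. Also open, on these data alone, is how a phenyl ring without any methyl group would read at this place, and what a longer chain would do with the 4-methylbenzyl group kept.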